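A few compounds are considered here, and "the series" means these few. Any claim that something is new, unique, unknown or untested is made for them only; others in the source may bear on it.

Compound 3 `CC(=O)c1ccc(-c2cn3ccnc3c(-c3ccc4ncn(C5CCCCC5)c4c3)n2)cc1` gives 0.73% in a functional assay on MDA-MB-468 cells (Homo sapiens) for inhibition, read by sulforhodamine B assay, with a stated time of 48 h, tested at 10 uM (on this read-out lower numbers stand for less inhibition and higher numbers for more inhibition at the one concentration tested (going by the name of the read-out)), the lowest of the three numbers measured. Compound 1 `Fc1ccc(-c2cn3ccnc3c(-c3ccc4ncn(C5CCCCC5)c4c3)n2)cc1` gives 19.5%, and compound 2 `c1cn2cc(-c3ccsc3)nc(-c3ccc4ncn(C5CCCCC5)c4c3)c2n1` gives 21.8%. Compound 4 `Clc1ccc(-c2cn3ccnc3c(-c3ccc4ncn(C5CCCCC5)c4c3)n2)cc1` differs from compound 3 by chloro in place of acetyl on an aromatic carbon. The step that bears most directly on this is the reverse of a number 18.8 percentage points lower from compound 1 to compound 3 (beyond the scatter), where acetyl had replaced fluoro; the step of a number 21.1 percentage points lower from compound 2 to compound 3 (beyond the scatter) points the same way, while a number 2.3 percentage points higher from compound 1 to compound 2 (within the scatter) shows an exchange of one aryl group for another changing little. Chloro, like fluoro, is a halogen, so an upward step beyond the scatter is expected for compound 4, namely a number 17.3 percentage points higher from compound 3 to compound 4 (beyond the scatter). Compound 4 is therefore estimated at 18%, within a range from 5% to 32%.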

Compound 4, a percentage reported as inhibition, at one concentration (the size of the read-out at that concentration, not a potency) in the MDA-MB-468 assay: 10.6%
Compound 4: middle estimate off by 7.4 percentage points, on the high side; low and high end bracket the measured number.
By their numbers in the MDA-MB-468 assay, from the lowest: compounds 3, 4, 1 and 2 (each within the scatter of the next, the first and the last beyond it).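

In the MDA-MB-468 assay, the exchange at this place, para to a large group, reads a number 9.9 percentage points higher from compound 3 to compound 4 (within the scatter), so chloro does not clearly separate from acetyl, and the halogen exchange reads a number 8.9 percentage points lower from compound 1 to compound 4 (within the scatter). Yet 4-chlorophenyl does separate from thiophen-3-yl, with a number 11.2 percentage points lower from compound 2 to compound 4 (beyond the scatter), which 4-fluorophenyl did not. In a physicochemical assay for lipophilicity, using the shake flask method, in phosphate buffer, measured as octanol-water partition, with a stated time of 85 min, at pH 7.4 (a lower number here means a more polar compound, a higher number a more lipophilic compound), compound 3 gives 2.06 and compound 4 gives 1.51, and the chloro for acetyl exchange does register: the measured partition coefficient of compound 3, 2.06, and of compound 4, 1.51, a number 0.55 log units lower (beyond the scatter)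

From the compounds shown here alone, what an amine or a carboxylic acid at this place would give in the MDA-MB-468 assay stays open. So does whether any group here goes well beyond the low inhibition seen so far.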